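The source may report more compounds than this note shows. Statements on the series, on what has been measured and on what is new or still open speak of the compounds shown alone.

Working notes on the series. Compound 1 `O=[N+]([O-])c1cn2c(n1)OC[C@@H](NCc1ccc(OC(F)(F)F)c(Cl)c1)C2` is the amine with a chloro substituent next to the aryl ether; in an in vitro ADME assay on the whole organism (microsomes, liver, Mus musculus) for metabolic stability, read by LC-MS, with a stated time of 24 h, at a dose of 5 mg/kg by the intravenous route (on this read-out higher numbers stand for fast clearance and lower numbers for slow clearance), compound 1 gives 103 mL.min-1.g-1. Compound 3 `CN(Cc1ccc(OC(F)(F)F)cc1)[C@@H]1COc2nc([N+](=O)[O-])cn2C1`, a methylated amine, gives 125 mL.min-1.g-1 in this assay, a number within the scatter of compound 1, so the two cannot be ordered. Going by the values given here, compound 2 `CCCN(Cc1ccc(OC(F)(F)F)cc1)[C@@H]1COc2nc([N+](=O)[O-])cn2C1`, the propyl analogue, gives 407 mL.min-1.g-1, well beyond the scatter above both; the one measured step, a 3.3-fold lower number from compound 2 to compound 3 (0.51 log units; beyond the scatter), concerns the substituent on the amine nitrogen only.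

Compound 4 `O=[N+]([O-])c1cn2c(n1)OC[C@@H](NCc1ccc(OC(F)(F)F)c(Oc3ccccc3)c1)C2` differs from compound 1 by phenoxy in place of chloro on an aromatic carbon. Among the compounds with values here, no measured step touches this aromatic position, so the propyl-to-methyl step of compound 2 and compound 3 gives no direct guidance, and the expectation rests only on the closeness of compound 1 and compound 3. A moderate rise in clearance is expected, a 2.1-fold higher number from compound 1 to compound 4 (0.33 log units; beyond the scatter), with wide uncertainty. The estimate for compound 4 in this assay is 220 mL.min-1.g-1, between 80 mL.min-1.g-1 and 600 mL.min-1.g-1.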

Compound 4, intrinsic clearance in microsomes: 149 mL.min-1.g-1
Estimate against measurement, compound 4: 1.5-fold (0.17 log units) above; the range from low to high includes it.
By their numbers in this assay, from the lowest: compounds 1, 3 and 4 (each within the scatter of the next); then compound 2.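

At the aromatic carbon ortho to a trifluoromethoxy group, phenoxy in place of chloro adds a six-membered aromatic ring and raises the group from 1 heavy atom to 7 heavy atoms, yet in this assay the two compounds cannot be ordered (a 1.4-fold higher number from compound 1 to compound 4 (0.16 log units; within the scatter)). Going by these compounds alone, this is the first measured step at this aromatic position, as the earlier step concerned only the substituent on the amine nitrogen, and here a much larger group leaves the read-out within the scatter. No measurement bearing on the reason for this result is available.

From the compounds shown here alone, whether an amine or a carboxylic acid on this aromatic carbon would also stay within the scatter of compound 1 remains open. Also open, going by these compounds, is whether a propyl group on the amine nitrogen of compound 1 or compound 4 would give a step like the one between the two tertiary amines.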